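Hydrogen in place of amino in compound 1

The source may report more compounds than this note shows. Statements on the series, on what has been measured and on what is new or still open speak of the compounds shown alone.

Compound 1 (`Nc1nc2cc(Cl)c(Cl)cc2n1COCCO`) has no exact number in a functional assay on KB cells (Homo sapiens) for inhibition; a lower number here means a stronger inhibitor, a higher number a weaker inhibitor. Compound 1 gives > 100000 nM, which is a limit of the assay. Compound 2 (`CN(C)c1nc2cc(Cl)c(Cl)cc2n1COCCO`) gives > 100000 nM, which is also a limit. The series therefore crowds at one end, with the limit of > 100000 nM in this assay, at which 2 of the 3 values shown sit. Only compound 3 (`OCCOCn1c(SCc2ccccc2)nc2cc(Cl)c(Cl)cc21`) gives a number, with compound 3 at 55000 nM.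

The unmeasured compound 4 (`OCCOCn1cnc2cc(Cl)c(Cl)cc21`) differs from compound 1 as follows: hydrogen in place of amino on an aromatic carbon. Three measured steps change the same aromatic carbon. Dimethylamino gives a step that the two limits leave unreadable from compound 1 to compound 2. Benzylsulfanyl gives an at least 1.8-fold lower number from compound 1 to compound 3 (0.25 log units; that floor lies within the scatter), and it also gives an at least 1.8-fold lower number from compound 2 to compound 3 (0.25 log units; that floor lies within the scatter).

None of these steps offers a firm size to carry over. Going by the values given here, the one number comes from compound 3 at 55000 nM, which carries benzylsulfanyl, whereas hydrogen brings no heavy atom. In this assay, no clear change is therefore expected, and compound 4 should stay close to compound 1. The expected step is an at least 1.1-fold lower number from compound 1 to compound 4 (0.04 log units; that floor lies within the scatter). For compound 4 the estimated value is 90000 nM, with an expected range of 35000 nM to 200000 nM.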

Compound 4, half-maximal inhibitory concentration: > 100000 nM
Compound 4 was reported as a limit (the forecaster's own chance of this, stated with the estimate: 55%); middle value at least 1.1-fold (0.04 log units) away from the limit.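

In this assay compound 4 gives > 100000 nM, which is a limit of the assay. Hydrogen on this aromatic carbon thus joins amino and dimethylamino at the same end of the series, leaving compound 3, with benzylsulfanyl, as the only compound shown with a number: the limit of > 100000 nM in this assay, at which 3 of the 4 values shown sit. Hydrogen in place of benzylsulfanyl gives an at least 1.8-fold higher number from compound 3 to compound 4 (0.25 log units; that floor lies within the scatter), while the steps from compound 1 and from compound 2 to compound 4 cannot be read.

On these data alone, it remains open whether a methylsulfanyl, benzyloxy or benzylamino group on this aromatic carbon would also give a number in this assay. As far as these compounds go, it is equally open whether a longer chain in place of the (2-hydroxyethoxy)methyl group would change the reading for compound 3 or compound 4.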